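The source may hold more compounds than are shown below. What is called first, only, known or untested is meant among the compounds shown, and "the series" means these compounds.

In an ADME assay (liver) for metabolic stability, with Liver microsome (Homo sapiens) as the target, using microsomes and NADPH, with a stated time of 30 min, tested at 1 uM (on this read-out higher numbers stand for fast clearance and lower numbers for slow clearance), compound 1 (`Nc1ccc(S(=O)(=O)N2CCN(c3ncc(C(O)(C(F)(F)F)C(F)(F)F)cc3C3CC3)CC2)cn1`) gives 38 mL.min-1.g-1 and compound 2 (`Nc1ccc(S(=O)(=O)N2CCN(c3ncc(C(O)(C(F)(F)F)C(F)(F)F)cc3-c3ccc4scnc4c3)CC2)cn1`) gives 39 mL.min-1.g-1 in the same series. Within the data shown here, compound 2 thus stands level with compound 1 within the scatter, and these are the only two numbers so far. Compound 3 (`Nc1ccc(S(=O)(=O)N2CCN(c3ncc(C(O)(C(F)(F)F)C(F)(F)F)cc3-c3cc4ccccc4[nH]3)CC2)cn1`) is still unmeasured and carries 1H-indol-2-yl in place of 1,3-benzothiazol-5-yl on an aromatic carbon ortho to a large group. Among the measured compounds shown here, one measured step bears on this place, with 1,3-benzothiazol-5-yl in place of cyclopropyl, and because of a 1.0-fold higher number from compound 1 to compound 2 (0.01 log units; within the scatter) no step beyond the scatter is expected in this assay here. For the measured compounds named here, no measured compound carries 1H-indol-2-yl, and a single step is thin support, so the range is kept wide. The estimated 1.0-fold higher number from compound 2 to compound 3 (0.01 log units; within the scatter) is accordingly small. Compound 3 is expected at 40 mL.min-1.g-1 with an estimated range from 22 mL.min-1.g-1 to 75 mL.min-1.g-1 around that middle.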

Compound 3, intrinsic clearance in microsomes: < 14 mL.min-1.g-1
Compound 3: no number, only a limit; the forecaster's own chance of this, stated with the estimate: 3%; middle value at least 2.8-fold (0.45 log units) away from the limit.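

In this assay, the value of compound 3 is a limit of the assay and not a number: the limit of < 14 mL.min-1.g-1 in this assay, at which 1 of the 3 values shown sits.

Even so, the position ortho to a large group proves responsive to what it carries, with an at least 2.7-fold lower number from compound 2 to compound 3 (0.44 log units; beyond the scatter) and an at least 2.7-fold lower number from compound 1 to compound 3 (0.43 log units; beyond the scatter), whereas the only earlier step, a 1.0-fold higher number from compound 1 to compound 2 (0.01 log units; within the scatter), gave no sign of this. The two groups exchanged in the first of these new steps match in heavy-atom count and differ in that 1H-indol-2-yl carries a hydrogen-bond donor, so heavy-atom count alone does not follow the read-out across compound 2 and compound 3.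

As far as these compounds go, how far the true value of compound 3 lies past its limit remains open, as does whether the donor hydrogen or the point of attachment of 1H-indol-2-yl goes with the change. From the compounds shown here alone, how a simple phenyl or an amine at this position would read is also open.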